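Nitro for Hydrogen on a Phenyl Ring of Compound 1

The source may report more compounds than this note shows. Statements on the series, on what has been measured and on what is new or still open speak of the compounds shown alone.

Of the compounds shown here, three sharing one core have been tested in an assay for inhibition of Polyunsaturated fatty acid 5-lipoxygenase (Homo sapiens), read by spectrophotometry, tested at 10 uM, in the presence of a further agent that is not named here; a lower number here means less inhibition, a higher number more inhibition at the concentration tested (going by the name of the read-out). Compound 1 `Cc1nc(NC(=O)c2ccccc2)sc1C(=O)/C=C/c1ccccc1` gives 73.5%, which stands second highest of the three numbers. Compound 2 `Cc1nc(NC(=O)c2ccccc2)sc1C(=O)/C=C/c1ccc(F)cc1`, carrying fluoro in place of hydrogen on an aromatic carbon, gives 98%, so the step of a number 24.5 percentage points higher from compound 1 to compound 2 (beyond the scatter) lies beyond the scatter. Compound 3 `Cc1nc(NC(=O)c2ccccc2)sc1C(=O)/C=C/c1cccc(Br)c1`, carrying bromo in place of hydrogen on an aromatic carbon, gives 42.5%, and the step of a number 31 percentage points lower from compound 1 to compound 3 (beyond the scatter) is large and also beyond the scatter; between those two substituted compounds the step of a number 55.5 percentage points lower from compound 2 to compound 3 (beyond the scatter) is larger still.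

Compound 4 `Cc1nc(NC(=O)c2ccccc2)sc1C(=O)/C=C/c1cccc([N+](=O)[O-])c1` differs from compound 1 by nitro in place of hydrogen on an aromatic carbon. Of the measured steps, a number 31 percentage points lower from compound 1 to compound 3 (beyond the scatter) bears most directly on it, as bromo there also entered meta to a large group, while the fluoro step went the other way at a different place. The account therefore expects a downward step a number 21.5 percentage points lower from compound 1 to compound 4 (beyond the scatter), beyond the scatter. Compound 4 is estimated at 52%, within 28% to 76%.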

Compound 4, a percentage reported as inhibition, at one concentration (the size of the read-out at that concentration, not a potency): 98%
Estimate against measurement, compound 4: 46 percentage points below; measured number above the stated range.
By their numbers in this assay, from the lowest: compound 3; then compound 1; then compounds 2 and 4 (each within the scatter of the next).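

In this assay the ring place that took bromo in compound 3 proves not to be one where any added group lowers the number, since nitro there gives a number 24.5 percentage points higher from compound 1 to compound 4 (beyond the scatter) and so runs opposite to the bromo step. With the place held fixed, exchanging bromo for nitro gives a number 55.5 percentage points higher from compound 3 to compound 4 (beyond the scatter), which ties the outcome at this place to the group that enters and not to substitution as such. The 3-nitrophenyl and 4-fluorophenyl groups cannot be told apart here, with no change at the digits printed from compound 2 to compound 4 (within the scatter) on record.

On these data alone, whether an amine or a carboxylic acid at this same place would follow nitro or bromo stays open. Nothing in the data shown accounts for the wide split between nitro and bromo.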